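The source may report more compounds than this note shows. Statements on the series, on what has been measured and on what is new or still open speak of the compounds shown alone.

Measured in a functional assay on HeLa cells (Homo sapiens) for antiproliferative activity, read by MTT assay, with a stated time of 48 h; on this read-out lower numbers stand for stronger inhibition and higher numbers for weaker inhibition:
Compound 1 `COc1ccc(-c2cc3c(cn2)[nH]c(=O)n3-c2cc(OC)c(OC)c(OC)c2)cn1`: 870 nM
Compound 2 `CCOc1ccc(-c2cc3c(cn2)[nH]c(=O)n3-c2cc(OC)c(OC)c(OC)c2)cc1`: 3730 nM
Compound 3 `COc1ccc(-c2cc3c(cn2)[nH]c(=O)n3-c2cc(OC)c(OC)c(OC)c2)cc1C(=O)O`: 5990 nM

The numbers show a 4.3-fold higher number from compound 1 to compound 2 (0.63 log units; beyond the scatter), beyond the scatter, and a 1.6-fold higher number from compound 2 to compound 3 (0.21 log units; within the scatter), within it, so compound 2 belongs to the weaker pair of this small set.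

Compound 4 `CCOc1ccc(-c2cc3c([nH]c(=O)n3-c3cc(OC)c(OC)c(OC)c3)c(C(N)=O)n2)cc1` has one change from compound 2: carbamoyl in place of hydrogen on an aromatic carbon, carbamoyl in place of hydrogen, next to the ring nitrogen. Going by the values given here, no measured compound carries a change at that place. Among the compounds with values here, the only guide is changes on the aromatic group elsewhere, the largest being a 6.9-fold higher number from compound 1 to compound 3 (0.84 log units; beyond the scatter). This gives no clear direction, so the expected outcome is an estimated 1.1-fold higher number from compound 2 to compound 4 (0.03 log units; within the scatter). The estimate for compound 4 is 4000 nM, with an expected range from 900 nM to 18000 nM.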

Compound 4, half-maximal inhibitory concentration: 4030 nM
Compound 4: the middle estimate sits 1.0-fold (0.00 log units) below what was measured, within the range that was stated.
By their numbers in this assay, from the lowest: compound 1; then compounds 2, 4 and 3 (each within the scatter of the next).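

Carbamoyl in place of hydrogen, next to the ring nitrogen, is the only change at this place among these compounds. In this assay it gives a 1.1-fold higher number from compound 2 to compound 4 (0.03 log units; within the scatter) and so leaves the number within the scatter, which shows that this position can carry the group alongside the 4-ethoxyphenyl group. Nothing available gives a reason for this result.

On these data alone, whether an amine, a carboxylic acid or a longer chain at this place would move the number remains open. So does whether carbamoyl would do the same alongside the 6-methoxypyridin-3-yl group of compound 1.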